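The source may report more compounds than this note shows. Statements on the series, on what has been measured and on what is new or still open speak of the compounds shown alone.

Measured so far:
Compound 1 `Oc1c(C(Nc2ccccc2)c2ccccc2)ccc2cccnc12` gives 8900 nM in an assay on isolated protein for inhibition of CAAX prenyl protease 2 (Homo sapiens), with stated times of 60 s and 60 min; a higher number here means a weaker inhibitor, a lower number a stronger inhibitor
Compound 2 `N#Cc1ccc(C(Nc2ccc(C(=O)O)cc2)c2ccc3cccnc3c2O)cc1` gives 16000 nM in this assay

Of the two numbers in this assay, compound 2 carries the higher one, but its gap to compound 1 lies within the usual scatter of repeated measurements, so the two compounds cannot be ranked against each other on this evidence.

Compound 3 `O=C(O)c1ccc(NC(c2ccc3cccnc3c2O)C2CCCCC2)cc1` has not yet been measured. It differs from compound 2 in one place: cyclohexyl in place of 4-cyanophenyl on a saturated chain carbon bound to an aromatic carbon and a nitrogen on an aromatic ring. For the measured compounds named here, no pair of measured compounds covers a change of this kind, so nothing measured here anchors the direction of the step in this assay; a modest shift either way, or none beyond the scatter, would be consistent with what is known.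

On that basis compound 3 is expected to give about 12000 nM in this assay, with an estimated range from 4000 nM to 40000 nM. The implied step, a 1.3-fold lower number from compound 2 to compound 3 (0.12 log units; within the scatter), is expected to stay small.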

Compound 3, half-maximal inhibitory concentration: 9800 nM
Compound 3: the middle estimate sits 1.2-fold (0.09 log units) above what was measured; low and high end bracket the measured number.
By their numbers in this assay, from the lowest: compounds 1, 3 and 2 (each within the scatter of the next).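

At the saturated chain carbon bound to an aromatic carbon and a nitrogen on an aromatic ring, cyclohexyl in place of 4-cyanophenyl gives a 1.6-fold lower number from compound 2 to compound 3 (0.21 log units; within the scatter) in this assay. For the compounds shown here, this is the first single-place comparison, and it shows that replacing the aromatic ring and its nitrile with a non-aromatic carbon ring produces no change that can be read at this position. Nothing measured here speaks to the reason for this result.

Going by these compounds, whether a methyl group or a piperidine ring at this place would move the number beyond the scatter remains open. Compound 1 differs from compound 2 and compound 3 in more than one place, so what the carboxylic acid alone contributes also stays unresolved.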